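The source may report more compounds than this note shows. Statements on the series, on what has been measured and on what is new or still open speak of the compounds shown alone.

Working notes on a small series sharing one core. Compound 1 `COc1ccc(CNc2nc([Se]C)nc3ccccc23)cc1` was measured in an ADME assay on BEAS-2B cells (Homo sapiens) for cytotoxicity, read by MTT assay, with a stated time of 72 h; on this read-out higher numbers stand for weaker inhibition of growth and lower numbers for stronger inhibition of growth; in this assay compound 1 gives only a limit, > 100000 nM. Compound 2 `CSc1nc(NCCCc2ccccc2)c2ccccc2n1` likewise gives only a limit in this assay, > 100000 nM. Compound 3 `CSc1ccc(CNc2nc([Se]C)nc3ccccc23)cc1` gives 78500 nM in this assay. Among the measured compounds shown here, the one measured step, an at least 1.2-fold lower number from compound 1 to compound 3 (0.10 log units; that floor lies within the scatter), is a change elsewhere in compound 1 and rests on the floor described by the limit of > 100000 nM in this assay, at which 2 of the 3 values shown sit. For the measured compounds named here, compound 1 thus stands at that floor, with no numeric value of its own and no other compound here clearly differing from it.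

Compound 4 `COc1ccc(CNc2nc(S)nc3ccccc23)cc1` differs from compound 1 by one sulfur atom in place of a group of 2 heavy atoms (1 carbon, 1 selenium; no ring), on an aromatic carbon. Going by the values given here, no measured step touches this position, so the only bearing comes from an at least 1.2-fold lower number from compound 1 to compound 3 (0.10 log units; that floor lies within the scatter), which is small and itself at the floor. In this assay no shift beyond the scatter is expected for this change. Compound 4 is therefore expected to give about 100000 nM, with a range from 30000 nM to 300000 nM, and most likely only a limit again. The step of a number no higher from compound 1 to compound 4 (the limit leaves the size open) is thus expected to be negligible.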

Compound 4, concentration for total growth inhibition: 32500 nM
Estimate against measurement, compound 4: 3.1-fold (0.49 log units) above; the measured number falls inside the stated range.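

In this assay, among the compounds shown here, the replacement on the aromatic carbon between two ring nitrogen atoms gives an at least 3.0-fold lower number from compound 1 to compound 4 (0.48 log units; beyond the scatter), whereas the only earlier step, an at least 1.2-fold lower number from compound 1 to compound 3 (0.10 log units; that floor lies within the scatter), did not clear the scatter. This position therefore responds to change, and exchanging the group of carbon and selenium for sulfanyl moves the number off the floor with the methoxy group left in place. The full size of the step stays open because compound 1 gives only a limit: the limit of > 100000 nM in this assay, at which 2 of the 4 values shown sit.

The compounds shown do not separate the loss of the carbon from the exchange of selenium for sulfur, and methylsulfanyl at this place on the core of compound 1 would address that. On these data alone, how an amine, a hydroxyl group or a longer chain on sulfur would read at this carbon also remains open.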